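Swapping a chlorophenyl for a methylfuran: one open step

The compounds below may be only part of what the source reports. "The series", "measured", "known", "first", "only" and "open" are said of these compounds alone.

Measured so far in a functional assay on L1210 cells (Mus musculus) for cytotoxicity, read by MTT assay, with a stated time of 24 h; on this read-out higher numbers stand for weaker inhibition and lower numbers for stronger inhibition:
- compound 1 `COc1cc(C(=O)/C=C/c2ccc3ccccc3c2)ccc1O` gives 54000 nM
- compound 2 `COc1cc(C(=O)/C=C/c2ccc(Cl)cc2)cc(OC)c1OC` gives 44500 nM
- compound 3 `CCCCOc1ccc(/C=C/C(=O)c2cc(OC)c(OC)c(OC)c2)cc1` gives > 100000 nM (a limit of the assay, not a number)

Only two of these compounds have actual numbers. Compound 1 (54000 nM) and compound 2 (44500 nM) lie within the usual scatter of each other, so neither can be ranked ahead. Compound 3 has only a limit (> 100000 nM).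

Compound 4 `COc1cc(C(=O)/C=C/c2ccc(C)o2)cc(OC)c1OC` has not been measured yet. It keeps the rest of compound 2 but carries this change: 5-methylfuran-2-yl in place of 4-chlorophenyl on a double-bonded chain carbon bound to a double-bonded chain carbon (in words, 5-methylfuran-2-yl in place of 4-chlorophenyl on a double-bonded chain carbon bound to a double-bonded chain carbon).

Within the data shown here, the one measured step starting from compound 2 is an at least 2.2-fold higher number from compound 2 to compound 3 (0.35 log units; beyond the scatter) (butoxy in place of chloro on an aromatic carbon). Among the measured compounds shown here, that is a different change from the one in compound 4, so it is only a loose guide, and it warns that the number can move upward. For the measured compounds named here, no measured step tests a furan.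

The expectation is therefore no shift beyond the scatter, with real uncertainty on the upper side. The estimated step is a 1.1-fold lower number from compound 2 to compound 4 (0.05 log units; within the scatter) (an expectation only). The estimate for compound 4 is 40000 nM (expected range 12000 nM to 100000 nM).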

Compound 4, half-maximal inhibitory concentration: 46500 nM
Compound 4: the middle estimate sits 1.2-fold (0.07 log units) below what was measured, within the range that was stated.
By their numbers in this assay, from the lowest: compounds 2, 4 and 1 (each within the scatter of the next). At a limit, above all of these: compound 3.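

In this assay, putting 5-methylfuran-2-yl in place of 4-chlorophenyl on a double-bonded chain carbon bound to a double-bonded chain carbon gives a 1.0-fold higher number from compound 2 to compound 4 (0.02 log units; within the scatter), so at this position a five-membered aromatic ring with 1 hetero atom cannot be told apart from the six-membered carbon ring. Among these compounds, the only earlier step between compounds that differ in one place exchanged a group on the ring and kept the ring itself, whereas this change replaces the whole ring, removes the chlorine and adds a hydrogen-bond acceptor, and the two numbers still lie within the scatter of each other. Compound 3 remains the only compound here that stands at a limit rather than at a number: the limit of > 100000 nM in this assay, at which 1 of the 4 values shown sits.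

What the compounds shown leave open is whether the methyl group on the furan matters, since a furan without it does not appear among them, and whether a thiophene or a pyridine ring would behave in the same way. Going by these compounds, it is also open whether a ring carrying an amine or a carboxylic acid at this place would move the number beyond the scatter in either direction.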